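A few compounds are considered here, and "the series" means these few. Any claim that something is new, unique, unknown or untested is made for them only; others in the source may bear on it.

Compound 1 `Cc1ccc(C(=O)NC2CCCCCC2)c(=O)n1Cc1ccc(F)cc1` was tested in an assay on HEK293 cells for inhibition of Lysophosphatidylserine lipase ABHD12 (Homo sapiens), read by scintillation counting, with stated times of 30 min and 5 min (a lower number here means a stronger inhibitor, a higher number a weaker inhibitor), where compound 1 gives > 10000 nM; this is a limit of the assay, not a number. Compound 2 `Cc1nc(OCc2ccc(F)cc2)c(C(=O)NC2CCCCCC2)cc1-c1ccc(F)cc1` in this assay gives > 10000 nM, likewise only a limit. As the limit of > 10000 nM in this assay, at which 2 of the 2 values shown sit, shows, every value shown stops at that limit, so compound 1 cannot be placed more precisely than at it. Compound 3 `Cc1c(F)cc(C(=O)NC2CCCCCC2)c(=O)n1Cc1ccc(F)cc1` differs from compound 1 by fluoro in place of hydrogen on an aromatic carbon. No measured step sizes such a change here, so compound 3 is expected to stay near the limit, with an expected step that the limit leaves unreadable from compound 1 to compound 3 not beyond the scatter. For compound 3 the estimated value is 12000 nM, ranging from 4000 nM to 40000 nM.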

Compound 3, half-maximal inhibitory concentration: > 10000 nM
Compound 3 was reported as a limit; the forecaster's own chance of this, stated with the estimate: 75%; the middle value does not contradict the limit.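

No step can be read from compound 1 to compound 3, since both values are only limits: the limit of > 10000 nM in this assay, at which 3 of the 3 values shown sit.
The compounds shown leave open how strongly any of them acts in this assay and whether fluoro in place of hydrogen changes that.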